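This account rests on a few compounds, and the source may have more. Where it says the series, first, only, none or still open, it means among the compounds named here.

In a functional assay on Hs 683 cells (Homo sapiens) for cytotoxicity, read by MTT assay, with a stated time of 72 h (a higher number here means a weaker inhibitor, a lower number a stronger inhibitor), compound 1 `O=C1CC(c2c(-c3ccc[nH]3)[nH]c3ccccc23)C(=O)N1` gives 25000 nM and compound 2 `COc1ccc2[nH]c3c4cn[nH]c4c4c(c3c2c1)C(=O)NC4=O` gives 45000 nM, two numbers within the usual scatter of each other. Compound 3 `O=C1NC(=O)c2c1c1c3cc(O)ccc3[nH]c1c1cccn21` is recorded only as a limit, > 100000 nM. Compound 4 `O=C1NC(=O)c2c1c1[nH]ncc1c1[nH]c3ccccc3c21` is still unmeasured. It differs from compound 2 by hydrogen in place of methoxy on an aromatic carbon of a six-membered aromatic ring of carbon only (hydrogen in place of methoxy on an aromatic carbon). For the measured compounds named here, no two measured compounds differ in one place, so the series offers no direct precedent for this change. With compound 2 at 45000 nM as the anchor, no shift beyond the scatter is expected in either direction. The expected step is a 1.1-fold lower number from compound 2 to compound 4 (0.05 log units; within the scatter). For compound 4 the estimated value in this assay is 40000 nM, with an expected range of 15000 nM to 100000 nM.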

Compound 4, half-maximal inhibitory concentration: 93000 nM
The estimate for compound 4 lay 2.3-fold (0.37 log units) below the measured number; the measured number falls inside the stated range.
By their numbers in this assay, from the lowest: compounds 1 and 2 (each within the scatter of the next); then compound 4. At a limit, above all of these: compound 3.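

In this assay, for the compounds shown here, the series now has its only step between compounds that differ in one place: hydrogen in place of methoxy on this aromatic carbon gives a 2.1-fold higher number from compound 2 to compound 4 (0.32 log units; beyond the scatter), modest but beyond the scatter. At this position, the methoxy form therefore carries the lower number, though one pair sets no trend. Compound 3 stands only as a limit: the limit of > 100000 nM in this assay, at which 1 of the 4 values shown sits.

As far as these compounds go, whether an amine or a longer alkoxy chain on this carbon would lower the number further remains open. So does whether the methoxy step carries over to the core of compound 1.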